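A few compounds are considered here, and "the series" means these few. Any claim that something is new, unique, unknown or untested is made for them only; others in the source may bear on it.

Measured in a functional assay on U-87MG ATCC cells for antiproliferative activity against U-87 MG (Homo sapiens), read by MTT assay, with a stated time of 48 h, tested at 10 uM; on this read-out lower numbers stand for a stronger effect and higher numbers for a weaker effect at the one concentration tested:
- compound 1, `COc1ccc(-c2nc(C)c(C(=O)CSc3nc(-c4cccc(OC)c4)c(C#N)c(=O)[nH]3)s2)cc1`: 66.7%
- compound 2, `Cc1nc(-c2ccc(Cl)cc2)sc1C(=O)CSc1nc(-c2cccc(Cl)c2)c(C#N)c(=O)[nH]1`: 95.2%
- compound 3, `COc1cccc(-c2nc(SCC(=O)c3sc(-c4ccc(Cl)cc4)nc3C)[nH]c(=O)c2C#N)c1`: 89.7%

Compound 2 gives the highest number of the three in this assay; compound 3 sits close to it, within the scatter, while compound 1 lies well apart, beyond the scatter. Compound 4, `COc1ccc(-c2nc(C)c(C(=O)CSc3nc(-c4cccc(Cl)c4)c(C#N)c(=O)[nH]3)s2)cc1`, has not been measured. It differs from compound 2 in one place: methoxy in place of chloro on an aromatic carbon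

Within the data shown here, two measured steps bear on this. The step of a number 23 percentage points higher from compound 1 to compound 3 (beyond the scatter) is the same exchange at the same place, run in the opposite direction, and it was a modest step beyond the scatter. The step of a number 5.5 percentage points lower from compound 2 to compound 3 (within the scatter) concerns the other aryl ring and stayed within the scatter, so it sets no direction of its own. Reversing the first step suggests that compound 4 should read lower than compound 2 in this assay, by a modest amount beyond the scatter, the expected step being a number 23.2 percentage points lower from compound 2 to compound 4 (beyond the scatter). Checked from the other side, compound 4 would stand near compound 1, since the remaining difference between them mirrors the small step from compound 3 to compound 2. Compound 4 is therefore expected to give about 72% in this assay, within a range of 58% to 86%.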

Compound 4, a percentage reported as activity, at one concentration (the size of the read-out at that concentration, not a potency): 90.6%
For compound 4 the middle estimate is 18.6 percentage points below the measured one; the measured number lies above the stated range.
By their numbers in this assay, from the lowest: compound 1; then compounds 3, 4 and 2 (each within the scatter of the next).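

In this assay, the change from 4-chlorophenyl to 4-methoxyphenyl gives a number 4.6 percentage points lower from compound 2 to compound 4 (within the scatter), so with chloro on the other aryl ring this position sets no direction of its own. The exchange on the other aryl ring shows the same dependence, with a number 23.9 percentage points higher from compound 1 to compound 4 (beyond the scatter) when the 4-methoxyphenyl group is present, while compound 2 and compound 3, both carrying 4-chlorophenyl, stay within the scatter of each other: the same change on two cores in this assay, a number 5.5 percentage points lower (within the scatter) from compound 2 to compound 3 and a number 23.9 percentage points lower (beyond the scatter) from compound 4 to compound 1, 18.4 percentage points apart, beyond the scatter of two such steps The two exchanges therefore do not add up across these compounds, and compound 1, the only one with methoxy on both aryl rings, stands alone, the size of the step at this position depending on the group on the other ring: the same change on two cores in this assay, a number 23 percentage points higher (beyond the scatter) from compound 1 to compound 3 and a number 4.6 percentage points higher (within the scatter) from compound 4 to compound 2, 18.4 percentage points apart, beyond the scatter of two such steps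

As far as these compounds go, whether that lower number needs methoxy itself at both places remains open, since a single pair of groups is compared at each place, and an amine or a hydroxyl in place of the methoxy of compound 1 would test this. These are also readings at one concentration in one cell line, so they leave the potency of compound 1 open.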